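Swapping a trichlorophenyl for an indole on a weak growth inhibitor

This account rests on a few compounds, and the source may have more. Where it says the series, first, only, none or still open, it means among the compounds named here.

Of the compounds shown here, three have been tested so far in a functional assay on DU-145 cells (Homo sapiens) for inhibition, read by trypan blue exclusion, with a stated time of 96 h; on this read-out lower numbers stand for stronger inhibition of growth and higher numbers for weaker inhibition of growth. Compound 1, with the structure `Cc1ccc(S/C(=C/c2cc(Cl)cc(Cl)c2Cl)C(=O)c2ccc(Cl)cc2)cc1`, gives 50000 nM in this assay. Compound 2, `O=C(O)c1ccc(C(=O)/C(=C\c2ccc([N+](=O)[O-])c(O)c2)SCc2ccc(Br)cc2)cc1`, gives 10000 nM, and compound 3, `COc1ccccc1/C=C(\C(=O)c1ccc(Cl)cc1)S(=O)(=O)Cc1ccc(C)cc1`, gives 10000 nM. Compound 1 therefore shows the highest number of the three, meaning the weakest inhibition of growth, and its gap to each of the other two lies beyond the usual scatter of repeated measurements. None of these three compounds differs from another in only one place, so no single structural step can be read off among them.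

The next compound to be measured is compound 4, `Cc1ccc(S/C(=C/c2c[nH]c3ccccc23)C(=O)c2ccc(Cl)cc2)cc1`. It is built on the same core as compound 1 and differs from it in one place: 1H-indol-3-yl in place of 2,3,5-trichlorophenyl on a double-bonded chain carbon bound to a double-bonded chain carbon. Among the measured compounds shown here, no measured pair shows what such a change does in this assay, so the expectation rests on compound 1 alone. Since compound 1 already sits at the weak end of the range seen here, the step from it to compound 4 is expected to be a moderate move toward stronger inhibition, a 2.0-fold lower number from compound 1 to compound 4 (0.30 log units; within the scatter), though a result within the scatter would not be surprising. Compound 4 is therefore estimated to give 25000 nM, with a plausible range from 6000 nM to 80000 nM.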

Compound 4, concentration for 50% growth inhibition: 10000 nM
Compound 4: middle estimate off by 2.5-fold (0.40 log units), on the high side; low and high end bracket the measured number.
By their numbers in this assay, from the lowest: compounds 2, 3 and 4 (each within the scatter of the next); then compound 1.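

In this assay, among the compounds shown here, the change from 2,3,5-trichlorophenyl to 1H-indol-3-yl gives the first single-place comparison in this set, with a 5.0-fold lower number from compound 1 to compound 4 (0.70 log units; beyond the scatter). This shows that the group on this double-bonded chain carbon can alter growth inhibition on the core of compound 1, even though the two groups have the same heavy-atom count and neither carries a net charge. Nothing measured here explains why the number falls, so the step stands as an observation about this one pair.

The swap removes the three chlorines, adds a five-membered ring containing nitrogen, and introduces a hydrogen-bond donor all at once, so these single pair results cannot show which of those differences matters. An unsubstituted phenyl would show what happens with the chlorines gone and no indole present, while a pyridyl or an indole bearing a methyl on its nitrogen would help separate the role of the ring from that of the amine hydrogen.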